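The source may report more compounds than this note shows. Statements on the series, on what has been measured and on what is new or still open speak of the compounds shown alone.

Compound 1 `COc1cccc2c1OCN(c1ccc3oc(-c4ccccc4)cc(=O)c3c1)C2` stands highest of the two numbers available. In a functional assay on MCF7 cells (Homo sapiens) for inhibition, read by MTT assay, with a stated time of 48 h, tested at 7.5 ug/mL (on this read-out lower numbers stand for less inhibition of growth and higher numbers for more inhibition of growth at the one concentration tested), compound 1 gives 32.5%. Its nearest neighbour, compound 2 `Cc1cc(C)c2c(c1)CN(c1ccc3c(=O)cc(-c4ccccc4)oc3c1)CO2`, gives 11.3% in this assay, a number that falls below compound 1 by more than the usual scatter. Compound 3 `O=c1cc(-c2ccccc2)oc2cc(N3COc4c(cccc4[N+](=O)[O-])C3)ccc12` is reported in this assay only as "not active" (no number reported), without a number. Compound 4 `O=c1cc(-c2ccccc2)oc2ccc(N3COc4c(cccc4[N+](=O)[O-])C3)cc12` has not been measured. It differs from compound 1 in one respect: nitro in place of methoxy on an aromatic carbon, a nitro in place of methoxy on an aromatic carbon. Among the measured compounds shown here, no measured pair shows this change directly, but compound 3, which also carries the nitro, gives "not active" (no number reported) in this assay. The step of a number 20.5 percentage points lower from compound 1 to compound 4 (beyond the scatter) is therefore expected to run downward, beyond the scatter. Compound 4 is estimated at 12%, within a range from 0% to 28%.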

Compound 4, percent growth inhibition at one concentration: 8.2%
Compound 4: middle estimate off by 3.8 percentage points, on the high side, within the range that was stated.
By their numbers in this assay, from the lowest: compounds 4 and 2 (each within the scatter of the next); then compound 1.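

At this place on the core of compound 1, ortho to a fused ring and meta to a fused ring, the change from methoxy to nitro now has a direct reading in this assay and gives a number 24.3 percentage points lower from compound 1 to compound 4 (beyond the scatter) in a single matched pair. The earlier compounds shown here offered no pair that differed only in this way. No measurement shown accounts for this step.

Going by these compounds, whether an amine or a carboxylic acid at this place would keep or lower growth inhibition remains open. So does whether a longer alkoxy chain would do so.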